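The source may report more compounds than this note shows. Statements on the series, on what has been measured and on what is new or still open speak of the compounds shown alone.

Compound 3, with the structure `CN(C)CCN1CCN(CC(=O)Nc2ccc(-c3nc4cc(F)ccc4o3)cc2)CC1`, and compound 1, with the structure `CN(C)CCN1CCN(CC(=O)Nc2ccc(-c3nc4ccccc4o3)cc2)CC1`, differ only in one respect: hydrogen in place of fluoro on an aromatic carbon. In a functional assay on MCF7 cells (Homo sapiens) for cytotoxicity, read by MTT assay, with a stated time of 24 h (a higher number here means a weaker inhibitor, a lower number a stronger inhibitor), compound 3 gives 20800 nM. In this assay compound 1 gives 59400 nM, a step of a 2.9-fold higher number from compound 3 to compound 1 (0.46 log units; beyond the scatter).

Compound 2, with the structure `Cc1cc(-c2nc3cc(F)ccc3o2)ccc1NC(=O)CCl`, carries a different core from compound 3; the difference between the two cores is not broken down here. In this assay compound 2 gives only a limit, > 100000 nM, and no number.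

Compound 4, with the structure `Cc1cc(-c2nc3ccccc3o2)ccc1NC(=O)CCl`, has not yet been measured in this assay. It differs from compound 2 by the same change as that from compound 3 to compound 1: hydrogen in place of fluoro on an aromatic carbon. Because that change gave a 2.9-fold higher number from compound 3 to compound 1 (0.46 log units; beyond the scatter), and because compound 2 already sits at the limit of > 100000 nM in this assay, at which 1 of the 3 values shown sits, compound 4 is expected to be weaker still and most likely to return only a limit. The step expected is a step that the limit leaves unreadable from compound 2 to compound 4. The estimate for compound 4 is 250000 nM, with a range from 100000 nM to 700000 nM.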

Compound 4, half-maximal inhibitory concentration: 29800 nM
The estimate for compound 4 lay 8.4-fold (0.92 log units) above the measured number; measured number below the stated range.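

In this assay, hydrogen in place of fluoro moves the number in opposite directions on the two cores, and on the core of compound 2 it gives an at least 3.3-fold lower number from compound 2 to compound 4 (0.52 log units; beyond the scatter). Set side by side, the two steps do not match: the same change on two cores in this assay, a 2.9-fold higher number (0.46 log units; beyond the scatter) from compound 3 to compound 1 and an at least 3.3-fold lower number (0.52 log units; beyond the scatter) from compound 2 to compound 4, at least 9.5-fold (0.98 log units) apart, beyond the scatter of two such steps

Compound 2 has only a limit, > 100000 nM, so the second step has a known minimum size but no exact size. These two pairs show that the result of this change on one core did not predict its result on the other, but they do not show why, and they give no rule for any further core.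

Going by these compounds, it remains open how either core would respond to a methoxy group or a nitrile on the same aromatic carbon. Also open, on these data alone, is which difference between the cores matters, whether the methyl group on the core of compound 2 or the chloroacetamide chain in place of the piperazine chain of compound 3.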